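A Nitro Group Replaces Trifluoromethyl on the Shared Core

The source may report more compounds than this note shows. Statements on the series, on what has been measured and on what is new or still open speak of the compounds shown alone.

Values in a functional assay on A549 cells (Homo sapiens) for antiproliferative activity, read by MTT assay, with a stated time of 72 h; a higher number here means a weaker inhibitor, a lower number a stronger inhibitor:
compound 1 `COc1ccc(/C=C/C(=O)/C=C/c2nc(C)c(C)nc2C)cc1` gives 3500 nM
compound 2 `Cc1nc(C)c(/C=C/C(=O)/C=C/c2ccccc2)nc1C` gives 12300 nM
compound 3 `Cc1nc(C)c(/C=C/C(=O)/C=C/c2ccc(C(F)(F)F)cc2)nc1C` gives 11700 nM
compound 4 `Cc1nc(C)c(/C=C/C(=O)/C=C/c2ccc([N+](=O)[O-])cc2)nc1C` awaits measurement

Compound 3 stands with the higher pair of numbers: the series shows a 1.1-fold lower number from compound 2 to compound 3 (0.02 log units; within the scatter) and also a 3.3-fold higher number from compound 1 to compound 3 (0.52 log units; beyond the scatter) on the methoxy side. Within the data shown here, the next change is nitro in place of trifluoromethyl on an aromatic carbon and no measured step covers this exchange directly. The closest evidence is the hydrogen exchange (a 1.1-fold lower number from compound 2 to compound 3 (0.02 log units; within the scatter)), while only the methoxy of compound 1 stands apart (a 3.5-fold higher number from compound 1 to compound 2 (0.55 log units; beyond the scatter)). The expected step in this assay is therefore none beyond the scatter, slightly downward if anything (a 1.2-fold lower number from compound 3 to compound 4 (0.09 log units; within the scatter)). The estimate for compound 4 is 9500 nM (expected range 4500 nM to 18000 nM).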

Compound 4, half-maximal inhibitory concentration: 9600 nM
For compound 4 the middle estimate is 1.0-fold (0.00 log units) below the measured one; the range from low to high includes it.
By their numbers in this assay, from the lowest: compound 1; then compounds 4, 3 and 2 (each within the scatter of the next).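

In this assay, nitro on this aromatic carbon cannot be told apart from trifluoromethyl (a 1.2-fold lower number from compound 3 to compound 4 (0.09 log units; within the scatter)) or from hydrogen (a 1.3-fold lower number from compound 2 to compound 4 (0.11 log units; within the scatter)), so the three compounds now form one group. Methoxy remains the only group of the four that stands apart, with the step to nitro beyond the scatter (a 2.7-fold higher number from compound 1 to compound 4 (0.44 log units; beyond the scatter)). No evidence shown here explains this grouping.

On these data alone, whether an amine or a hydroxyl on this carbon would match methoxy remains open. So does whether methoxy would stand apart elsewhere on the ring.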